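Chloro on the benzyl ring in a dihydropyrimidine series

This account rests on a few compounds, and the source may have more. Where it says the series, first, only, none or still open, it means among the compounds named here.

Measured compounds:
compound 1, `CC1=C(C(=O)Nc2ccc(F)cc2)C(c2ccc([N+](=O)[O-])cc2)N=C(SCc2ccccc2)N1`: 12.3%
compound 2, `CC1=C(C(=O)Nc2ccc(F)cc2)C(c2ccc([N+](=O)[O-])cc2)N=C(SCc2cccc(Cl)c2)N1`: 7.2%
compound 3, `CC1=C(C(=O)Nc2ccc([N+](=O)[O-])cc2)C(c2cccc([N+](=O)[O-])c2)N=C(SCc2ccccc2)N1`: 7.7%

In a functional assay on the whole organism (artery, strain albino) with Rattus norvegicus as the target, with a stated time of 60 min, at a dose of 10 mg/kg by the oral route (a lower number here means less inhibition, a higher number more inhibition at the dose given (going by the name of the read-out)), compound 1 gives 12.3% and compound 2 gives 7.2%. The change from compound 1 to compound 2 is chloro in place of hydrogen on an aromatic carbon, and it made a number 5.1 percentage points lower from compound 1 to compound 2 (within the scatter). Compound 3 has a different core from compound 1; the difference between the two cores is not broken down here. In this assay compound 3 gives 7.7%, a number within the scatter of both compound 1 and compound 2.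

Compound 4, `CC1=C(C(=O)Nc2ccc([N+](=O)[O-])cc2)C(c2cccc([N+](=O)[O-])c2)N=C(SCc2ccccc2Cl)N1`, is not yet measured. It differs from compound 3 by chloro in place of hydrogen on an aromatic carbon. This is the same kind of change as that from compound 1 to compound 2, not the same one: there the chloro enters meta to a large group, here ortho to a large group. The step it made before, from compound 1 to compound 2, was within the scatter.

The step from compound 3 to compound 4 is expected to be a number 1.7 percentage points lower from compound 3 to compound 4 (within the scatter), resting on a number 5.1 percentage points lower from compound 1 to compound 2 (within the scatter) and on compound 3 already giving 7.7%. For compound 4 the estimate in this assay is 6%, between 0% and 16%.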

Compound 4, a percentage reported as inhibition, in the whole organism at one dose (the size of the read-out at that dose, not a potency): 6.7%
Estimate against measurement, compound 4: 0.7 percentage points below; the measured number falls inside the stated range.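

In this assay, chloro in place of hydrogen gave a number 1 percentage points lower from compound 3 to compound 4 (within the scatter). Set beside the earlier step, the change shows no difference between the two cores that can be told apart: the same change on two cores in this assay, a number 5.1 percentage points lower (within the scatter) from compound 1 to compound 2 and a number 1 percentage points lower (within the scatter) from compound 3 to compound 4, 4.1 percentage points apart, within the scatter of two such steps. For the compounds shown here, this does not show that the change has the same effect on both cores, nor that it has any effect on either: only two steps are at hand, each lies within the scatter, and the chloro does not stand at the same place in the two.

The compounds shown leave open whether another group on the benzyl ring, such as a methoxy group, an amine or a carboxylic acid, would move the inhibition beyond the scatter. They also leave open what a longer alkyl chain in place of the benzyl on the sulfur would do on either core.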